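Swapping the chlorophenyl for a methylphenyl on the anilino nitrogen

The compounds below may be only part of what the source reports. "The series", "measured", "known", "first", "only" and "open" are said of these compounds alone.

Of the compounds shown here, two built on the same core have been measured in a functional assay on B16-F10 cells (Mus musculus) for inhibition, read by MTT assay, with a stated time of 72 h; on this read-out higher numbers stand for weaker inhibition and lower numbers for stronger inhibition. Compound 1, `C#CCSc1nc(Nc2ccc(Cl)cc2)c(C#N)c(-c2ccccc2)n1`, gives 19800 nM. Compound 2, `N#Cc1c(Nc2cccc(Cl)c2)nc(SCc2cn(Cc3ccccc3Cl)nn2)nc1-c1ccccc1`, gives 3590 nM, the lower of the two numbers and therefore the stronger inhibition shown so far; compound 1 sits well above it, beyond the usual scatter of this assay. These two compounds differ in more than one place, so no single change can be tied to that gap.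

Compound 3, `Cc1ccccc1Nc1nc(SCc2cn(Cc3ccccc3Cl)nn2)nc(-c2ccccc2)c1C#N`, is not yet measured. It keeps the whole of compound 2 except for one change: 2-methylphenyl in place of 3-chlorophenyl on a nitrogen on an aromatic ring. Within the data shown here, no measured pair isolates a change of this kind here, so the expectation rests on the change being small in size and the rest of the molecule unchanged. The step expected from compound 2 to compound 3 is a 1.5-fold higher number from compound 2 to compound 3 (0.19 log units; within the scatter), a modest weakening that may still fall within the scatter. Compound 3 is therefore expected to give about 5500 nM in this assay, within a range of 1800 nM to 17000 nM.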

Compound 3, half-maximal inhibitory concentration: 2760 nM
Beside the measured number, compound 3's estimate is 2.0-fold (0.30 log units) above it; the range from low to high includes it.
By their numbers in this assay, from the lowest: compounds 3 and 2 (each within the scatter of the next); then compound 1.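

Among these compounds, the first comparison at a single place, in this assay, gives a 1.3-fold lower number from compound 2 to compound 3 (0.11 log units; within the scatter), so 3-chlorophenyl and 2-methylphenyl on this nitrogen cannot be told apart in this read-out. Among the compounds shown here, both the group on the ring and its place on the ring differ in this swap, so the pair shows only that the two changes taken together leave the number within the usual scatter. Nothing measured here bears on why this swap gives such a small step.

Still open, going by these compounds, is how a plain phenyl, a methoxyphenyl or a phenyl carrying a carboxylic acid would read on this nitrogen, and whether chlorine and methyl would still match at the same place on the ring. Also unresolved is which of the several differences between compound 1 and compound 2 accounts for the gap between their numbers.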